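Trading methoxy for chloro: what to expect for compound 3

The source may report more compounds than this note shows. Statements on the series, on what has been measured and on what is new or still open speak of the compounds shown alone.

Measured so far:
Compound 1, `COc1cc(/C=C/C(=O)c2cccc(-n3cc(-c4ccccc4)[nH]c3=O)c2)ccc1O`, gives 1850 nM in a functional assay on SK-MEL-28 cells (Homo sapiens) for inhibition; a higher number here means a weaker inhibitor of growth, a lower number a stronger inhibitor of growth.
Compound 2, `COc1ccc(-c2cn(-c3cccc(C(=O)/C=C/c4ccc(O)c(OC)c4)c3)c(=O)[nH]2)cc1`, gives 2030 nM in this assay.

Of the compounds shown here, two have been measured, and their numbers sit within the usual scatter of each other. The single measured step, a 1.1-fold higher number from compound 1 to compound 2 (0.04 log units; within the scatter), did not move the read-out beyond that scatter, so for this pair of compounds the shared core decides the number and the substituent on the outer ring has not shown an effect.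

Compound 3, `COc1cc(/C=C/C(=O)c2cccc(-n3cc(-c4ccc(Cl)cc4)[nH]c3=O)c2)ccc1O`, is the next compound in this series. It differs from compound 2 in one place: chloro in place of methoxy on an aromatic carbon. Going by the values given here, no measured step involves a chloro group, so the only guide is that the step from compound 1 to compound 2 at this same carbon stayed within the scatter. The change from compound 2 to compound 3 is therefore expected to stay within the scatter too, with no clear direction, as a 1.0-fold lower number from compound 2 to compound 3 (0.01 log units; within the scatter). On that basis compound 3 is estimated at 2000 nM in this assay, with a range from 900 nM to 4500 nM.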

Compound 3, concentration for 50% growth inhibition: 2060 nM
Beside the measured number, compound 3's estimate is 1.0-fold (0.01 log units) below it, within the range that was stated.
By their numbers in this assay, from the lowest: compounds 1, 2 and 3 (each within the scatter of the next).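

In this assay the step of a 1.0-fold higher number from compound 2 to compound 3 (0.01 log units; within the scatter) and the step of a 1.1-fold higher number from compound 1 to compound 3 (0.05 log units; within the scatter) extend what the earlier pair showed, which was only that methoxy and hydrogen on this aromatic carbon read alike. Chloro now joins them: at this carbon, para to a large group, the three compounds stay within the scatter of one another, even though chloro brings 1 heavy atom and 0 hydrogen-bond acceptors where methoxy brings 2 heavy atoms and 1 hydrogen-bond acceptor, so in this small set the number does not follow either count. Nothing measured in this study speaks to why these groups read alike.

Going by these compounds, whether this carbon tolerates any group at all remains open, since an amine, a carboxylic acid or a longer chain such as butoxy could still move the number beyond the scatter. All three compounds also share the same core, including its methoxy and hydroxy groups on the other aromatic ring, so they cannot show whether changes elsewhere in the molecule matter more than this one.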